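The source may report more compounds than this note shows. Statements on the series, on what has been measured and on what is new or still open speak of the compounds shown alone.

Measured compounds:
compound 1, `OC[C@@]1(c2ccc(F)cc2)NC[C@@H](O)[C@@H]1O`, 714000 nM
compound 2, `OC[C@]1(c2ccccc2)NC[C@H](O)[C@H]1O`, 630 nM
compound 3, `COc1ccc([C@@]2(CO)NC[C@H](O)[C@H]2O)cc1`, 601000 nM

In an assay on isolated protein for inhibition of lysosomal alpha-glucosidase (Homo sapiens) (a higher number here means a weaker inhibitor, a lower number a stronger inhibitor), compound 3 stands second highest of the three numbers. Its nearest neighbour is compound 1, whose value lies within the scatter of that of compound 3, so no order between these two can be read. Compound 2 stands far apart: the step of a 950-fold higher number from compound 2 to compound 3 (2.98 log units; beyond the scatter) came with methoxy in place of hydrogen on an aromatic carbon, a large step toward weaker inhibition.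

Compound 4, `OC[C@]1(c2ccc(O)cc2)NC[C@H](O)[C@H]1O`, differs from compound 3 by hydrogen in place of methyl on an oxygen on an aromatic ring; cut one bond further out, the change reads methoxy to hydroxy. Among the measured compounds shown here, no measured step shows a hydroxy on this ring, so the only step that bears on it is the one from compound 2 to compound 3, which shows how much the methoxy as a whole costs. Removing its methyl leaves an oxygen on the ring, and part of that cost may remain. The number for compound 4 in this assay is therefore expected to fall below that of compound 3 but to stay well above compound 2, a step estimated as a 6.0-fold lower number from compound 3 to compound 4 (0.78 log units; beyond the scatter). Compound 4 is estimated at 100000 nM, in the range 15000 nM to 500000 nM.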

Compound 4, half-maximal inhibitory concentration: 376000 nM
Estimate against measurement, compound 4: 3.8-fold (0.58 log units) below; low and high end bracket the measured number.
By their numbers in this assay, from the lowest: compound 2; then compounds 4, 3 and 1 (each within the scatter of the next).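

In this assay, methoxy to hydroxy gives a 1.6-fold lower number from compound 3 to compound 4 (0.20 log units; within the scatter), so taking off the methyl brings no readable recovery. The step of a 600-fold higher number from compound 2 to compound 4 (2.78 log units; beyond the scatter) is large, as is a 950-fold higher number from compound 2 to compound 3 (2.98 log units; beyond the scatter), which places the large step with the oxygen on the aromatic ring in both compounds and not with the methyl alone. Nothing available explains why this oxygen goes with so large a step.

The compounds shown leave open whether an amine or a methyl in place of that oxygen would stay close to compound 2 or show a similarly large step. They also leave open whether a longer chain on the oxygen, such as ethoxy, would stay within the scatter of compound 3.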